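Removing a Methyl from an Aromatic Oxygen

The compounds below may be only part of what the source reports. "The series", "measured", "known", "first", "only" and "open" are said of these compounds alone.

Measured so far in a physicochemical assay, read by spectrophotometry; on this read-out lower numbers stand for stronger inhibition and higher numbers for weaker inhibition:
Compound 1 `COc1cc(/C=N/NC(=O)c2ccncc2)cc(OC)c1O` gives 17000 nM.
Compound 2 `COc1cc(/C=N/NC(=O)OCc2ccccc2)cc(OC)c1O` gives 60500 nM.
Compound 3 `COc1cc(/C=N/NC(=O)OCc2ccccc2)cc(OC)c1OC` reaches only a limit of the assay, > 1000000 nM.

Between the first two stands a 3.6-fold higher number from compound 1 to compound 2 (0.55 log units; beyond the scatter). Compound 3 sits at the limit of > 1000000 nM in this assay, at which 1 of the 3 values shown sits. Compound 2 arises from compound 3 by hydrogen in place of methyl on an oxygen on an aromatic ring, a step of an at least 16-fold lower number from compound 3 to compound 2 (1.21 log units; beyond the scatter). How the cores of compound 1 and compound 3 differ is not broken down here.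

Compound 4 `COc1cc(/C=N/NC(=O)c2ccncc2)cc(O)c1O` is not yet measured. It arises from compound 1 by hydrogen in place of methyl on an oxygen on an aromatic ring, the same change at the same kind of place as from compound 3 to compound 2. Because the earlier step of an at least 16-fold lower number from compound 3 to compound 2 (1.21 log units; beyond the scatter) was large, a large step is expected here too, though its size rests on a limit. For compound 4 the expected step is an 8.5-fold lower number from compound 1 to compound 4 (0.93 log units; beyond the scatter). Compound 4 is estimated at 2000 nM, probably between 500 nM and 8000 nM.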

Compound 4, half-maximal inhibitory concentration: 18400 nM
Compound 4: middle estimate off by 9.2-fold (0.96 log units), on the low side, and the stated range ends below it.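

In this assay, hydrogen in place of methyl on an oxygen on an aromatic ring gives a 1.1-fold higher number from compound 1 to compound 4 (0.03 log units; within the scatter), so this pair shows no measurable effect of the change, unlike the earlier step of an at least 16-fold lower number from compound 3 to compound 2 (1.21 log units; beyond the scatter). The size of a step therefore did not carry over from one core to the other here, though two pairs cannot show how the change behaves across the wider series or why the two cores differ. Compound 3 gives only a limit, not a true number, so the full size of the earlier step stays unknown: the limit of > 1000000 nM in this assay, at which 1 of the 4 values shown sits.

From the compounds shown here alone, whether an ethyl group on that oxygen would behave like methyl remains open. So does the effect of an amine or a carboxylic acid in place of the hydroxy group on either core.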